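Swapping the benzyl ring on a benzimidazole series

The source may hold more compounds than are shown below. What is called first, only, known or untested is meant among the compounds shown, and "the series" means these compounds.

Three compounds share one core and differ at two points. Compound 1 `CCC(=O)N1CCN(Cc2nc3ccccc3n2Cc2cccc(C)c2)CC1` gives 85.1% in an assay on isolated protein for inhibition of aldehyde dehydrogenase 1A1 (Homo sapiens), read by spectrophotometry, tested at 10 uM (on this read-out lower numbers stand for less inhibition and higher numbers for more inhibition at the one concentration tested (going by the name of the read-out)), compound 2 `O=C(C1CC1)N1CCN(Cc2nc3ccccc3n2Cc2ccccc2C(F)(F)F)CC1` gives 56.3%, and compound 3 `Cc1cccc(Cn2c(CN3CCN(C(=O)c4ccc(Br)cc4)CC3)nc3ccccc32)c1` gives 25.8%. Compound 2 therefore stands second highest of the three, beyond the scatter from both neighbours. Among the measured compounds shown here, the one measured single step, a number 59.3 percentage points lower from compound 1 to compound 3 (beyond the scatter), concerns the carbonyl substituent, not the ring that changes here. Compound 4 `COc1cccc(Cn2c(CN3CCN(C(=O)C4CC4)CC3)nc3ccccc32)c1` differs from compound 2 by 3-methoxyphenyl in place of 2-(trifluoromethyl)phenyl on a saturated chain carbon bound to an aromatic nitrogen. For the measured compounds named here, no measured step bears on this change, so the direction rests only on compound 1, whose 3-methylphenyl ring sits at the same place and gives 85.1%. A modest rise, a number 8.7 percentage points higher from compound 2 to compound 4 (within the scatter), is expected. Compound 4 is estimated at 65%, between 40% and 85%.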

Compound 4, a percentage reported as inhibition, at one concentration (the size of the read-out at that concentration, not a potency): 44.4%
Compound 4: middle estimate off by 20.6 percentage points, on the high side; the measured number falls inside the stated range.
By their numbers in this assay, from the lowest: compound 3; then compound 4; then compound 2; then compound 1.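

The first step read at this ring, with the rest of the molecule held the same, is a number 11.9 percentage points lower from compound 2 to compound 4 (beyond the scatter) in this assay and it shows that the number responds to which ring sits on this saturated chain carbon. Here, 3-methoxyphenyl gives less inhibition than 2-(trifluoromethyl)phenyl. Nothing measured on these compounds explains the drop.

Still open, from the compounds shown here alone, is how a plain phenyl ring or a pyridine ring would fare at this place. Also open, going by these compounds, is whether this swap gives a similar step with ethyl on the carbonyl carbon.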